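Swapping biphenyl for pyridine in a cytotoxicity series

A few compounds are considered here, and "the series" means these few. Any claim that something is new, unique, unknown or untested is made for them only; others in the source may bear on it.

Compound 1 `Cc1ccccc1C(c1ccccc1)N1CCN(c2ncnc3c2cnn3-c2ccccc2)CC1` gives in a functional assay on cells (Rhabdomyosarcoma cell, Homo sapiens) for cytotoxicity (on this read-out higher numbers stand for weaker inhibition and lower numbers for stronger inhibition), only a limit of the assay, > 25000 nM.
Compound 2 `FC(F)(F)c1ccc(C(c2ccccc2)N2CCN(c3ncnc4c3cnn4-c3ccccc3)CC2)cc1` gives in this assay only a limit, > 25000 nM.
Compound 3 `c1ccc(-c2ccc(C(c3ccccc3)N3CCN(c4ncnc5c4cnn5-c4ccccc4)CC3)cc2)cc1` gives in this assay only a limit, > 25000 nM.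

Compound 3 therefore stands at the edge of what this assay can report, as do the other two, since (the limit of > 25000 nM in this assay, at which 3 of the 3 values shown sit). The measured steps a step that the two limits leave unreadable from compound 1 to compound 2, a step that the two limits leave unreadable from compound 1 to compound 3 and a step that the two limits leave unreadable from compound 2 to compound 3 are all unreadable for the same reason, so they give no direction for the change to compound 4 `c1ccc(C(c2cccnc2)N2CCN(c3ncnc4c3cnn4-c3ccccc3)CC2)cc1`, which is pyridin-3-yl in place of 4-phenylphenyl on a saturated chain carbon bound to an amine nitrogen in a ring and an aromatic carbon. Among the measured compounds shown here, no step bearing on this change can be sized, so no shift beyond the scatter is expected; compound 4 is estimated to remain at the limit, 40000 nM, between 10000 nM and 200000 nM, a step that the limit leaves unreadable from compound 3 to compound 4.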

Compound 4, half-maximal inhibitory concentration: > 25000 nM
Compound 4 ended at the assay's limit (the forecaster's own chance of this, stated with the estimate: 80%); the middle value does not contradict the limit.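

Compound 1, compound 2, compound 3 and compound 4 all sit at the same limit, so none of the steps among them can be read: the limit of > 25000 nM in this assay, at which 4 of the 4 values shown sit.
These compounds leave open which change on the saturated chain carbon, if any, would give a true number in this assay.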